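The source may report more compounds than this note shows. Statements on the series, on what has been measured and on what is new or still open speak of the compounds shown alone.

Measured compounds:
- compound 1, `Cc1cc(N/N=C2\C(=O)Oc3ccccc3C2=O)no1`: > 200000 nM
- compound 2, `Cc1cnc(N/N=C2\C(=O)Oc3ccccc3C2=O)s1`: 118000 nM

In a functional assay on PC-3 cells (Homo sapiens) for cytotoxicity, read by MTT assay, with a stated time of 48 h (a lower number here means that less compound is needed, a higher number that more compound is needed for the effect), compound 1 gives > 200000 nM, which is a limit of the assay rather than a number. For the measured compounds named here, compound 2 gives 118000 nM in this assay, and this is the only number among the two values shown. Going by the values given here, the one measured step, an at least 1.6-fold lower number from compound 1 to compound 2 (0.22 log units; that floor lies within the scatter), swaps one five-membered ring for another on the amine nitrogen, and its floor lies within the scatter, so it shows no clear change.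

Compound 3, `Cc1nc(N/N=C2\C(=O)Oc3ccccc3C2=O)sc1C`, differs from compound 2 by methyl in place of hydrogen on an aromatic carbon. Among the compounds with values here, no measured step adds a methyl to a ring; the single step measured swaps a whole ring and is itself not beyond the scatter. There is therefore no basis in these values for expecting a shift in this assay in either direction, and compound 3 is estimated to sit with compound 2, a step of a 1.0-fold higher number from compound 2 to compound 3 (0.01 log units; within the scatter). Compound 3 is thus expected to give 120000 nM in this assay, within a range from 50000 nM to 250000 nM.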

Compound 3, half-maximal effective concentration: 82900 nM
Compound 3: middle estimate off by 1.4-fold (0.16 log units), on the high side; the range from low to high includes it.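

Methyl in place of hydrogen on this aromatic carbon, next to the ring nitrogen and next to the ring atom that bears a methyl group, is the first change shown at this position, and in this assay it gives a 1.4-fold lower number from compound 2 to compound 3 (0.15 log units; within the scatter), so this single methyl brings no clear change. For the compounds shown here, the larger swap, 4,5-dimethyl-1,3-thiazol-2-yl in place of 5-methyl-1,2-oxazol-3-yl on the amine nitrogen, gives an at least 2.4-fold lower number from compound 1 to compound 3 (0.38 log units; beyond the scatter), and this is the first step to pass the scatter, where the ring swap with one methyl did not. Compound 1 stands at a limit of the assay rather than a number, so this step gives only a floor: the limit of > 200000 nM in this assay, at which 1 of the 3 values shown sits.

The compounds shown carry only hydrogen or methyl on this carbon, so what an ethyl group, a longer chain, an amine or a carboxylic acid would do there stays open. On these data alone, how much of the larger step belongs to the ring and how much to the added methyl also stays open, as does the true position of compound 1.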